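A few compounds are considered here, and "the series" means these few. Any claim that something is new, unique, unknown or untested is made for them only; others in the source may bear on it.

Values in a functional assay on HCT-116 cells (Homo sapiens) for cytotoxicity, read by MTT assay, with a stated time of 72 h; on this read-out lower numbers stand for stronger inhibition and higher numbers for weaker inhibition:
- Compound 1 `N[C@H]1CC[C@H](Nc2c(C(=O)NCc3ccco3)nc(Br)c3cccnc23)CC1`: > 10000 nM, a limit of the assay and not a number
- Compound 2 `COc1cccc(CNC(=O)c2nc(Br)c3cccnc3c2N[C@H]2CC[C@H](N)CC2)c1`: 6000 nM
- Compound 3 `N[C@H]1CC[C@H](Nc2c(C(=O)NCc3ccccn3)nc(Br)c3cccnc23)CC1`: "not determined" (no result reported)

Compound 3 has no number in this assay, so it offers no starting value. Compound 4 `N[C@H]1CC[C@H](Nc2c(C(=O)NCc3ccccc3)nc(Br)c3cccnc23)CC1` differs from it in one place: phenyl in place of pyridin-2-yl on a saturated chain carbon bound to an amide-type nitrogen. This puts phenyl in place of pyridin-2-yl on a saturated chain carbon bound to an amide-type nitrogen. Among the compounds with values here, only one measured step changes that same place, and it swaps furan-2-yl for 3-methoxyphenyl: an at least 1.6-fold lower number from compound 1 to compound 2 (0.22 log units; that floor lies within the scatter). That gives no firm size or direction, so no step beyond the scatter is expected. The nearest measured guide is compound 2 at 6000 nM, which also carries a carbon-only aromatic ring there. For compound 4 the expected value is 7000 nM, with an estimated range from 3000 nM to 15000 nM.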

Compound 4, half-maximal inhibitory concentration: 7000 nM
Compound 4: the middle estimate sits on the measured number at the digits printed; the measured number falls inside the stated range.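

In this assay, methoxy on the aromatic ring makes no readable difference: hydrogen in its place gives (a 1.2-fold higher number from compound 2 to compound 4 (0.07 log units; within the scatter)). Phenyl in place of furan-2-yl also gives no firm separation (an at least 1.4-fold lower number from compound 1 to compound 4 (0.15 log units; that floor lies within the scatter)). That step is only a floor, since compound 1 stands at a limit and not a number: the limit of > 10000 nM in this assay, at which 1 of the 4 values shown sits. Still open, on these data alone, is whether an amine or a carboxylic acid on the phenyl ring, or a longer chain bound to the amide-type nitrogen, would move the number beyond the scatter.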